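This account rests on a few compounds, and the source may have more. Where it says the series, first, only, none or still open, it means among the compounds named here.

Three analogues built on one shared core have been measured in a functional assay on OVCAR-3 cells (Homo sapiens) for antiproliferative activity, read by spectrophotometry, with a stated time of 2 days; on this read-out lower numbers stand for stronger inhibition of growth and higher numbers for weaker inhibition of growth. Compound 1 `COc1ccc(Nc2ncc(C(F)(F)F)c(N3Cc4cccc(N(C)S(C)(=O)=O)c4C3)n2)cc1C(F)(F)F` returns only a limit in this assay, > 30000 nM. Compound 2 `CN(c1cccc2c1CN(c1nc(Nc3ccc(Cl)c(C(F)(F)F)c3)ncc1C(F)(F)F)C2)S(C)(=O)=O` likewise returns only a limit, > 50000 nM. Compound 3 `CN(c1cccc2c1CN(c1nc(Nc3cccc(Oc4ccccc4)c3)ncc1C(F)(F)F)C2)S(C)(=O)=O` gives 24900 nM in this assay. Among the measured compounds shown here, the single step between compounds differing in one place, a step that the two limits leave unreadable from compound 1 to compound 2, cannot be read, as the two limits the limit of > 30000 nM in this assay, at which 1 of the 3 values shown sits, and the limit of > 50000 nM in this assay, at which 1 of the 3 values shown sits, leave its size unknown. Compound 2 thus stands only at a limit, and nothing shown separates it from compound 1. Compound 4 `Cc1ccc(Nc2ncc(C(F)(F)F)c(N3Cc4cccc(N(C)S(C)(=O)=O)c4C3)n2)cc1C` differs from compound 2 by 3,4-dimethylphenyl in place of 4-chloro-3-(trifluoromethyl)phenyl on a nitrogen on an aromatic ring. For the measured compounds named here, no measured step bears on this change; with every value shown weak, no step beyond the scatter is expected. Compound 4 is estimated to give 30000 nM, within 8000 nM to 100000 nM. This estimate means an expected step of an at least 1.6-fold lower number from compound 2 to compound 4 (0.22 log units; that floor lies within the scatter), which is within the scatter.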

Compound 4, concentration for 50% growth inhibition: > 30000 nM
Compound 4: no number, only a limit; the forecaster's own chance of this, stated with the estimate: 50%; the middle value sits exactly at the limit.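

Among the compounds shown here, compound 4 returns only a limit, > 30000 nM, so no step from compound 1 or compound 2 to compound 4 can be read. The compounds shown leave open how compound 1, compound 2 and compound 4 truly rank in growth inhibition.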